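A few compounds are considered here, and "the series" means these few. Any claim that something is new, unique, unknown or untested is made for them only; others in the source may bear on it.

Among the compounds with values here, in a functional assay on MCF7 cells (Homo sapiens) for inhibition, read by MTT assay, with a stated time of 72 h (a higher number here means a weaker inhibitor, a lower number a stronger inhibitor), compound 1 `COc1ccc(-c2nnc(SCCCN3CCN(c4nc5ccccc5o4)CC3)o2)cc1` gives 52800 nM, the lower of the two numbers measured so far. Compound 2 `c1ccc(-c2nnc(SCCCN3CCN(c4nc5ccccc5o4)CC3)o2)cc1`, with hydrogen in place of methoxy on an aromatic carbon, gives 117000 nM. The change between them is a 2.2-fold higher number from compound 1 to compound 2 (0.35 log units; beyond the scatter), a modest step beyond the scatter. Compound 3 `COc1ccc(-c2nnc(SCCCN3CCN(c4nc5ccccc5s4)CC3)o2)cc1` has not yet been measured. It differs from compound 1 at one place: 1,3-benzothiazol-2-yl in place of 1,3-benzoxazol-2-yl on an amine nitrogen in a ring. Within the data shown here, the single measured step lies elsewhere in the molecule, so it serves only as a gauge of size, and no measured pair tests the exchange of 1,3-benzoxazol-2-yl for 1,3-benzothiazol-2-yl. The data give no direction for this change, so no step beyond the scatter is expected in this assay. The estimated step is a 1.1-fold lower number from compound 1 to compound 3 (0.02 log units; within the scatter). Compound 3 is expected at 50000 nM, with an estimated range from 20000 nM to 120000 nM.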

Compound 3, half-maximal inhibitory concentration: 171000 nM
Compound 3: middle estimate off by 3.4-fold (0.53 log units), on the low side; the measured number lies above the stated range.
By their numbers in this assay, from the lowest: compound 1; then compounds 2 and 3 (each within the scatter of the next).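

In this assay, the exchange on the amine nitrogen in a ring is not silent: 1,3-benzothiazol-2-yl in place of 1,3-benzoxazol-2-yl gives a 3.2-fold higher number from compound 1 to compound 3 (0.51 log units; beyond the scatter). This position therefore responds to sulfur replacing oxygen, even though the two groups match in heavy atom count, ring types, hydrogen-bond donors and hydrogen-bond acceptors. The step is graded modest, as is the methoxy change, a 2.2-fold higher number from compound 1 to compound 2 (0.35 log units; beyond the scatter), so two separate places on the core of compound 1 now each show a step beyond the scatter, and the data offer no explanation for the higher number with sulfur.

On these data alone, whether this exchange has the same effect when hydrogen replaces methoxy remains open. So does the outcome with a quite different group at this place, such as an acetyl group or a longer alkyl chain.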